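A few compounds are considered here, and "the series" means these few. Any claim that something is new, unique, unknown or untested is made for them only; others in the source may bear on it.

In a toxicity assay on NIH3T3 cells (Mus musculus) for cytotoxicity, read by resazurin assay (a higher number here means that more compound is needed for the effect, a lower number that less compound is needed), compound 1 `COC(=O)c1ccc(NCc2cncn2Cc2ccc(-c3ccccc3)cc2)cc1-c1ccccc1` gives only a limit, > 1000 nM, and not a number. Compound 2 `COC(=O)c1ccc(NCc2cncn2Cc2ccc(F)cc2)cc1-c1ccccc1` stands at "not determined" (no result reported), so no number fixes where it lies. Of the two values shown, one sits at the limit: the limit of > 1000 nM in this assay, at which 1 of the 2 values shown sits. Compound 3 `COC(=O)c1ccc(NCc2cncn2Cc2ccccc2[N+](=O)[O-])cc1-c1ccccc1` differs from compound 2 by 2-nitrophenyl in place of 4-fluorophenyl on a saturated chain carbon bound to an aromatic nitrogen. No step between measured compounds is shown, so the size of any shift in this assay cannot be read from them, and a change no larger than the scatter is expected in either direction. Compound 3 is expected to give about 1500 nM in this assay, with a likely range from 300 nM to 10000 nM.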

Compound 3, half-maximal effective concentration: 10000 nM
Compound 3: the middle estimate sits 6.7-fold (0.82 log units) below what was measured; low and high end bracket the measured number.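

For the compounds shown here, no step to compound 3 can be read in this assay: compound 1 gives only a limit, and compound 2 has no reported result. The compounds shown leave open how much 2-nitrophenyl in place of 4-fluorophenyl or 4-phenylphenyl shifts the read-out.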